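Moving one methyl on the aryl sulfonamide

The source may report more compounds than this note shows. Statements on the series, on what has been measured and on what is new or still open speak of the compounds shown alone.

In a functional assay on CHO-TAX 5-6 cells (Cricetulus griseus) for antiproliferative activity, read by sulforhodamine B assay, with a stated time of 48 h (a higher number here means a weaker inhibitor, a lower number a stronger inhibitor), compound 1 (`Cc1cccc(NS(=O)(=O)c2ccc(N3CCNC3=O)cc2)c1`) gives 150 nM, compound 2 (`CCc1cccc(NS(=O)(=O)c2ccc(N3CCNC3=O)cc2)c1`) gives 140 nM and compound 3 (`Cc1cc(C)cc(NS(=O)(=O)c2ccc(N3CCNC3=O)cc2)c1`) gives 120 nM, so compound 3 stands level with both others within the scatter. Compound 4 (`Cc1ccc(C)c(NS(=O)(=O)c2ccc(N3CCNC3=O)cc2)c1`) carries 2,5-dimethylphenyl in place of 3,5-dimethylphenyl on a sulfonamide nitrogen. The bearing steps, a 1.3-fold lower number from compound 1 to compound 3 (0.10 log units; within the scatter) and a 1.2-fold lower number from compound 2 to compound 3 (0.07 log units; within the scatter), are both within the scatter, as is a 1.1-fold lower number from compound 1 to compound 2 (0.03 log units; within the scatter). For the measured compounds named here, no measured compound carries 2,5-dimethylphenyl, so these steps guide the expectation only loosely. The expected step, a 1.3-fold higher number from compound 3 to compound 4 (0.12 log units; within the scatter), stays within the scatter, tilted cautiously toward a higher number in this assay. Compound 4 is estimated at 160 nM, with an expected range of 60 nM to 450 nM.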

Compound 4, half-maximal inhibitory concentration: 54 nM
Beside the measured number, compound 4's estimate is 3.0-fold (0.47 log units) above it; measured number outside the range, below it.
By their numbers in this assay, from the lowest: compound 4; then compounds 3, 2 and 1 (each within the scatter of the next).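

In this assay, for the compounds shown here, 2,5-dimethylphenyl on the sulfonamide nitrogen gives the first step beyond the scatter (a 2.2-fold lower number from compound 3 to compound 4 (0.35 log units; beyond the scatter)), with the same atoms joined differently. The steps (a 2.6-fold lower number from compound 2 to compound 4 (0.41 log units; beyond the scatter)) and (a 2.8-fold lower number from compound 1 to compound 4 (0.44 log units; beyond the scatter)) point the same way, so among these four compounds the arrangement of the methyl groups matters where the earlier changes did not. No measured evidence bears on the origin of this shift. Open, going by these compounds, is whether methoxy or chlorine in place of either methyl of the 2,5-dimethylphenyl keeps the lower number, and which methyl carries the step.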